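Ortho halogen swap on a diaminopyrimidine benzyl series

The source may report more compounds than this note shows. Statements on the series, on what has been measured and on what is new or still open speak of the compounds shown alone.

Measured compounds:
Compound 1 `Nc1ncc(Cc2ccccc2O)c(N)n1` — 89100 nM
Compound 2 `Nc1ncc(Cc2ccccc2F)c(N)n1` — 43700 nM

Both compounds were tested in an assay for inhibition of Dihydrofolate reductase (Gallus gallus); a higher number here means a weaker inhibitor, a lower number a stronger inhibitor. In this assay compound 1 gives 89100 nM and compound 2 gives 43700 nM. Within the data shown here, the only recorded step, a 2.0-fold lower number from compound 1 to compound 2 (0.31 log units; beyond the scatter), came with the change from hydroxy to fluoro on the aromatic carbon. Compound 2 thus stands at the lower of the two numbers, with compound 1 a step above it that lies beyond the scatter.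

Compound 3 `Nc1ncc(Cc2ccccc2Cl)c(N)n1` is not yet measured. It differs from compound 2 by chloro in place of fluoro on an aromatic carbon. Among the measured compounds shown here, no measured step exchanges one halogen for another, so the one step available, a 2.0-fold lower number from compound 1 to compound 2 (0.31 log units; beyond the scatter), bears on it only loosely, by showing that a change at this aromatic carbon can move the number by a modest amount. For compound 3 a similarly modest step is expected, a 1.7-fold lower number from compound 2 to compound 3 (0.24 log units; within the scatter), giving an estimated 25000 nM with a range from 8000 nM to 70000 nM.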

Compound 3, inhibition constant: 17400 nM
Estimate against measurement, compound 3: 1.4-fold (0.16 log units) above; low and high end bracket the measured number.
By their numbers in this assay, from the lowest: compound 3; then compound 2; then compound 1.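

Compound 3 shows that the number at this aromatic carbon also moves when one halogen is exchanged for another: this assay gives a 2.5-fold lower number from compound 2 to compound 3 (0.40 log units; beyond the scatter) for chloro in place of fluoro. Set against hydroxy, chloro gives a 5.1-fold lower number from compound 1 to compound 3 (0.71 log units; beyond the scatter) and so a wider span than the one step seen earlier, placing the three groups in the order chloro, fluoro, hydroxy from the lowest number to the highest. No evidence is available to explain why chloro gives the lowest number here.

From the compounds shown here alone, whether this order extends to bromo or iodo, or how a methyl or an amine would compare at the same carbon, remains open. Going by these compounds, all three compounds carry their group at this one place, so the effect of these groups elsewhere on the aromatic ring also remains unknown.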